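Selanyl to amino swap on the fused diazine core

The source may hold more compounds than are shown below. What is called first, only, known or untested is meant among the compounds shown, and "the series" means these compounds.

Two compounds of this series have numbers in a functional assay on CCRF-CEM cells (Homo sapiens) for cytotoxicity, read by MTT assay, with a stated time of 72 h; on this read-out higher numbers stand for weaker inhibition of growth and lower numbers for stronger inhibition of growth. Compound 1 `CCCCC[Se]c1nc(N)c2ccccc2n1` gives 68000 nM in this assay. Compound 2 `[SeH]c1nc([SeH])c2ccccc2n1` gives 6010 nM in this assay, the lowest of the two numbers, with compound 1 standing a gap beyond the scatter away. Among the measured compounds shown here, no step between measured compounds differing in one place exists here, so the two values show only that the pair differs widely.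

Compound 3 `Nc1nc([SeH])nc2ccccc12` is not yet measured in this assay. Relative to compound 2 it carries one nitrogen atom in place of one selenium atom, on an aromatic carbon. Since compound 1, which also carries an amino group on its core, gives 68000 nM, a move toward weaker growth inhibition is expected. The expected step of a 2.5-fold higher number from compound 2 to compound 3 (0.40 log units; beyond the scatter) is upward and beyond the scatter. Compound 3 is estimated at 15000 nM, with a range of 5000 nM to 50000 nM.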

Compound 3, concentration for total growth inhibition: 52400 nM
Beside the measured number, compound 3's estimate is 3.5-fold (0.54 log units) below it; measured number above the stated range.
By their numbers in this assay, from the lowest: compound 2; then compounds 3 and 1 (each within the scatter of the next).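

Amino in place of selenium on an aromatic carbon of the core carries a large cost in this assay: the step is an 8.7-fold higher number from compound 2 to compound 3 (0.94 log units; beyond the scatter) and gives the first single-change reading at this position. On the amino-bearing core, the group on the selenium hardly registers, with hydrogen in place of pentyl giving a 1.3-fold lower number from compound 1 to compound 3 (0.11 log units; within the scatter), so across these three compounds the amino swap carries the large step and the chain does not. Nothing available here explains either step.

Going by these compounds, whether the cost belongs to amino itself or to losing selenium stays open, and a methylamine, a hydroxyl or a sulfur atom at this position would separate the two. Also open, on these data alone, is whether a pentyl chain on selenium would matter on the core of compound 2, which keeps both selenium atoms.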